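This account rests on a few compounds, and the source may have more. Where it says the series, first, only, none or still open, it means among the compounds named here.

Compound 1 `CC1CCN(C2CCN(S(=O)(=O)c3ccc(C#N)cc3)CC2)CC1` is the point of departure. Going by the values given here, in a functional assay on DLD-1 cells (Homo sapiens) for antiproliferative activity, read by CellTiter-Glo, with a stated time of 72 h (a lower number here means a stronger inhibitor, a higher number a weaker inhibitor), compound 1 gives 2800 nM, the second highest of the three numbers measured so far. Compound 2 `CC1CCN(C2CCN(S(=O)(=O)c3cccc(N)c3)CC2)CC1` carries a 3-aminophenyl in place of the 4-cyanophenyl on the sulfonyl sulfur; in this assay compound 2 gives 3400 nM, and a 1.2-fold higher number from compound 1 to compound 2 (0.08 log units; within the scatter). Compound 3 `Cc1ccc(S(=O)(=O)N2CCC(N3CCC(C)CC3)CC2)cc1C` carries a 3,4-dimethylphenyl on the sulfonyl sulfur; in this assay compound 3 gives 24 nM, and a 120-fold lower number from compound 1 to compound 3 (2.07 log units; beyond the scatter). The step to compound 4 `CCCCOc1ccc(S(=O)(=O)N2CCC(N3CCC(C)CC3)CC2)cc1` alters the same aromatic ring: butoxy in place of cyano on an aromatic carbon. Both measured steps bear on it, since each also removes the cyano group, but they pull apart: the 3-aminophenyl replacement stayed within the scatter, while the 3,4-dimethylphenyl replacement lowered the number greatly. Butoxy matches neither group, so the outcome is uncertain, yet the precedent of compound 3 at 24 nM weighs toward a lower number. Compound 4 is therefore expected to show a 14-fold lower number from compound 1 to compound 4 (1.15 log units; beyond the scatter). The estimate for compound 4 is 200 nM, with a range from 30 nM to 1500 nM.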

Compound 4, half-maximal inhibitory concentration: 2300 nM
The estimate for compound 4 lay 12-fold (1.06 log units) below the measured number; measured number above the stated range.
By their numbers in this assay, from the lowest: compound 3; then compounds 4, 1 and 2 (each within the scatter of the next).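

In this assay, butoxy in place of cyano on an aromatic carbon, para to a large group, gives a 1.2-fold lower number from compound 1 to compound 4 (0.09 log units; within the scatter), so this longer chain at this place does no more than the cyano group did. Losing the cyano group therefore does not by itself lower the number: compounds 2 and 4 both lack it and stay within the scatter of compound 1, and only compound 3 goes against this, at 24 nM. Nothing measured here accounts for this outcome.

The compounds shown leave open whether a single methyl at this place would be enough to reach the number of compound 3, or whether both of its methyl groups are needed. They also leave open whether a shorter ether such as methoxy would behave like butoxy or like methyl.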